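The compounds below may be only part of what the source reports. "The series", "measured", "known", "first", "only" and "open" are said of these compounds alone.

Series notes, anti-inflammatory read-out. In a functional assay on the whole organism (strain Wistar albino) for inhibition, with Rattus norvegicus as the target, read by paw edema, with stated times of 1 h and 2 h, at a dose of 0.32 mmol/kg by the intraperitoneal route (on this read-out lower numbers stand for less inhibition and higher numbers for more inhibition at the one dose given (going by the name of the read-out)), compound 1 `COc1ccc(-c2nn(-c3ccc(Cl)cc3)cc2C=O)cc1` gives 63.1%, compound 2 `Cc1ccc(-c2nn(-c3ccc(Cl)cc3)cc2/C=N\c2ccc(Cl)cc2)cc1` gives 48.3% and compound 3 `COc1ccc(-c2nn(-c3ccc(Cl)cc3)cc2/C=N\c2ccccc2)cc1` gives 57.2%. Compound 3 thus stands second of the three numbers, with compound 1 and compound 2 both within the scatter of it. Going by the values given here, the one measured step, a number 5.9 percentage points lower from compound 1 to compound 3 (within the scatter), concerns the imine end and is within the scatter. Compound 4 `COc1ccc(-c2nn(-c3ccc(Cl)cc3)cc2/C=N\c2ccc(Cl)cc2)cc1` differs from compound 3 by chloro in place of hydrogen on an aromatic carbon. Among the compounds with values here, no measured step isolates this change; compound 2 carries the same 4-chlorophenyl imine but also a different group on the other ring, so its value alone cannot be read as the chloro effect. A step of a number 3.2 percentage points lower from compound 3 to compound 4 (within the scatter) is expected, none beyond the scatter. Compound 4 is estimated at 54%, range 44% to 64%.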

Compound 4, a percentage reported as inhibition, in the whole organism at one dose (the size of the read-out at that dose, not a potency): 69.6%
For compound 4 the middle estimate is 15.6 percentage points below the measured one; the measured number lies above the stated range.
By their numbers in this assay, from the lowest: compounds 2, 3, 1 and 4 (each within the scatter of the next, the first and the last beyond it).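

Phenyl to 4-chlorophenyl at the imine end gives a number 12.4 percentage points higher from compound 3 to compound 4 (beyond the scatter) in this assay, the first step at this end that lies beyond the scatter. With the 4-chlorophenyl imine held, methoxy in place of methyl gives a number 21.3 percentage points higher from compound 2 to compound 4 (beyond the scatter), so the group on the other ring also matters here, while the full change at the carbonyl end gives a number 6.5 percentage points higher from compound 1 to compound 4 (within the scatter) and separates the two compounds by no more than the scatter. Nothing available explains either step beyond the scatter. On these data alone, whether bromo or an amine in place of the chloro holds this level remains open, as does whether the chloro step recurs with methyl on the other ring.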